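This account rests on a few compounds, and the source may have more. Where it says the series, first, only, none or still open, it means among the compounds named here.

Compound 1 is `CCCCOc1ccc(-c2nc3ncccn3c2NC(C)C)cc1`, and in a toxicity assay on A549 cells (Homo sapiens) for cytotoxicity, read by luminescence and CellTiter-Glo, with a stated time of 48 h (a higher number here means that more compound is tolerated, a lower number that less compound is tolerated), compound 1 gives 68000 nM. Compound 2 is `CCCCOc1ccc(-c2nc3ncccn3c2N)cc1`, and in this assay compound 2 gives > 100000 nM, which is a limit of the measurement and not a number. Compound 3 is `CCCCOc1ccc(-c2nc3ncccn3c2Nc2ccc(F)cc2)cc1`, and in this assay compound 3 gives > 100000 nM, again a limit rather than a number.

All three share one core and differ only in the group carried on a nitrogen on an aromatic ring. Compound 3 sits at the limit of > 100000 nM in this assay, at which 2 of the 3 values shown sit, so the cells tolerated it up to the highest concentration tested; compound 2 sits there too, and only compound 1 yielded a finite number.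

Compound 4 is `CCCCOc1ccc(-c2nc3ncccn3c2NCc2c[nH]cn2)cc1` and is not yet measured in this assay. Its difference from compound 3 is (1H-imidazol-4-yl)methyl in place of 4-fluorophenyl on a nitrogen on an aromatic ring. Within the data shown here, two measured steps touch the same nitrogen: an at least 1.4-fold higher number from compound 1 to compound 3 (0.16 log units; that floor lies within the scatter) and a step that the two limits leave unreadable from compound 2 to compound 3. Hydrogen, isopropyl and 4-fluorophenyl at this position all left the compounds well tolerated, with two of them at the limit. A small heteroaromatic group linked through a single carbon is therefore expected to behave similarly, so the step of a number no higher from compound 3 to compound 4 (the limit leaves the size open) is estimated to stay within the scatter. Compound 4 is expected to give 100000 nM, with a range from 40000 nM to 200000 nM.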

Compound 4, half-maximal cytotoxic concentration: > 100000 nM
Compound 4 was reported as a limit; the forecaster's own chance of this, stated with the estimate: 55%; the middle value lies on the limit itself.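

Compound 4 also gives a limit and not a number, which puts a third group on this nitrogen at the same limit: the limit of > 100000 nM in this assay, at which 3 of the 4 values shown sit. The earlier compounds shown here carried only hydrogen, isopropyl or 4-fluorophenyl here, so this result extends the series to a five-membered aromatic ring with 2 hetero atoms, attached through a methyl link and bringing a hydrogen-bond donor and a hydrogen-bond acceptor that 4-fluorophenyl lacks, and in this assay this change still yields no finite number. Among these compounds, the one step that can be read is an at least 1.4-fold higher number from compound 1 to compound 4 (0.16 log units; that floor lies within the scatter), while the steps to compound 4 from the two other compounds at the limit cannot be read.

Compound 1, at 68000 nM, remains the only compound with a finite number, so the compounds shown do not tell how far groups on this nitrogen can separate from one another in this assay. As far as these compounds go, whether a longer chain such as n-octyl, or a group carrying a carboxylic acid or an aliphatic amine, would give a finite number on this nitrogen stays open.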